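This account rests on a few compounds, and the source may have more. Where it says the series, first, only, none or still open, it means among the compounds named here.

For the measured compounds named here, compound 2 `C[C@H](NC(=O)Nc1ccc(C(C)(C)C)cc1)c1ccccc1` stands lowest of the two numbers measured so far in an ADME assay on the whole organism with Oryza sativa as the target, tested at 1 uM (on this read-out higher numbers stand for a weaker effect at the one concentration tested and lower numbers for a stronger effect), giving 88%, while compound 1 `Cc1ccc(NC(=O)N[C@@H](C)c2ccccc2)cc1` gives 99% in this assay. Going by the values given here, the only step that bears on the next change is a number 11 percentage points lower from compound 1 to compound 2 (beyond the scatter), where a larger alkyl group on the aromatic carbon went with a lower number. Compound 3 `CCCCCc1ccc(NC(=O)N[C@@H](C)c2ccccc2)cc1` differs from compound 2 by pentyl in place of tert-butyl on an aromatic carbon, again a larger alkyl group. Compound 3 is therefore expected to show a modest lowering, a number 8 percentage points lower from compound 2 to compound 3 (within the scatter), giving an estimated 80% in this assay, in the range 62% to 96%.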

Compound 3, a percentage reported as activity, at one concentration (the size of the read-out at that concentration, not a potency): 98%
For compound 3 the middle estimate is 18 percentage points below the measured one; measured number outside the range, above it.
By their numbers in this assay, from the lowest: compounds 2, 3 and 1 (each within the scatter of the next, the first and the last beyond it).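

In this assay the change to pentyl gives a number 10 percentage points higher from compound 2 to compound 3 (within the scatter), and the comparison with the methyl compound gives a number 1 percentage points lower from compound 1 to compound 3 (within the scatter), so pentyl at this place cannot be told apart from either tert-butyl or methyl. For the compounds shown here, compound 3 thus goes against the idea that a larger alkyl group here simply goes with a lower number, and only the step between compound 1 and compound 2 stays beyond the scatter. Nothing available explains this result.

From the compounds shown here alone, whether branching of the chain matters more than its size remains open. An isopropyl or a cyclohexyl group at this place would bear on that.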